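The compounds below may be only part of what the source reports. "The series", "measured", "known", "first", "only" and "open" are said of these compounds alone.

Compound 1 `COc1ccc(CN(C(=O)CSc2ccccn2)c2cc(OC)c(OC)c(OC)c2)cc1`: 2410 nM
Compound 2 `COc1ccc(CN(C(=O)CCCSc2nc3ccccc3o2)c2cc(OC)c(OC)c(OC)c2)cc1`: 1290 nM
Compound 3 `COc1ccc(CN(C(=O)CCCCSc2nc3ccccc3o2)c2cc(OC)c(OC)c(OC)c2)cc1`: 1360 nM

In a functional assay on MGC-803 cells (Homo sapiens) for antiproliferative activity, read by MTT assay, with a stated time of 48 h (a higher number here means a weaker inhibitor, a lower number a stronger inhibitor), compound 2, at 1290 nM, lies within the scatter of the other two compounds. Compound 4 `COc1ccc(CN(C(=O)CSc2nc3ccccc3o2)c2cc(OC)c(OC)c(OC)c2)cc1` has not yet been measured. It differs from compound 2 by (1,3-benzoxazol-2-yl)sulfanyl in place of 2-((1,3-benzoxazol-2-yl)sulfanyl)ethyl on a saturated chain carbon bound to a carbonyl carbon. For the measured compounds named here, two measured steps bear on this change: the chain change in a 1.1-fold higher number from compound 2 to compound 3 (0.02 log units; within the scatter), and a 1.9-fold lower number from compound 1 to compound 2 (0.27 log units; within the scatter), where compound 1 carries (pyridin-2-yl)sulfanyl at that same place. Neither exceeds the scatter, so no step beyond it is expected in this assay. The expected result is a 1.2-fold higher number from compound 2 to compound 4 (0.07 log units; within the scatter). The estimate for compound 4 is 1500 nM, with an expected range from 600 nM to 3500 nM.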

Compound 4, half-maximal inhibitory concentration: 450 nM
Beside the measured number, compound 4's estimate is 3.3-fold (0.52 log units) above it; measured number outside the range, below it.
By their numbers in this assay, from the lowest: compound 4; then compounds 2, 3 and 1 (each within the scatter of the next).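

In this assay, (1,3-benzoxazol-2-yl)sulfanyl in place of 2-((1,3-benzoxazol-2-yl)sulfanyl)ethyl on a saturated chain carbon bound to a carbonyl carbon gives a 2.9-fold lower number from compound 2 to compound 4 (0.46 log units; beyond the scatter), so chain length matters here although the earlier chain step stayed within the scatter. With the chain unchanged, 1,3-benzoxazol-2-yl in place of pyridin-2-yl on a sulfur gives a 5.4-fold lower number from compound 1 to compound 4 (0.73 log units; beyond the scatter), which shows separately that the group on the sulfur counts. No measured evidence accounts for either step. As far as these compounds go, what remains open is whether an amine or an ether oxygen in place of the sulfur would keep this activity, and whether a chloro substituent on the 1,3-benzoxazol-2-yl group would.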